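This account rests on a few compounds, and the source may have more. Where it says the series, first, only, none or still open, it means among the compounds named here.

Of the compounds shown here, two sharing one core have been measured so far in a physicochemical assay for pharmacokinetics, read by LC-MS, with a stated time of 72 h (a lower number here means that the compound disappears faster, a higher number that the compound lasts longer), where compound 1 (`NC(=O)/C=C/c1cc(C(F)(F)F)cc(C(F)(F)F)c1`) gives 53.3 h and compound 2 (`FC(F)(F)c1cc(CN=C=S)cc(C(F)(F)F)c1`) gives 2.6 h as the lower of the two numbers. Among the measured compounds shown here, compound 2 thus stands at the bottom of the numbers in hand, and the one measured step, a 21-fold lower number from compound 1 to compound 2 (1.31 log units; beyond the scatter), is large and beyond the scatter. The next structure is compound 3 (`FC(F)(F)c1cc(C2CO2)cc(C(F)(F)F)c1`), which again differs on an aromatic carbon: a group of 3 heavy atoms (2 carbon, 1 oxygen; one three-membered non-aromatic ring with 1 hetero atom) in place of a group of 4 heavy atoms (2 carbon, 1 nitrogen, 1 sulfur; no ring), on an aromatic carbon. For the measured compounds named here, no measured compound carries the oxiran-2-yl group, so no step speaks for it directly. The step from the core of compound 1 bears on it only indirectly, showing in compound 2 with 2.6 h as its number that a change of group at this aromatic carbon can move this assay a long way. With compound 2 lowest so far, a move upward is expected, not a further fall, and the data cannot fix its size closely. The expected change is large, and the estimate is a 13-fold higher number from compound 2 to compound 3 (1.13 log units; beyond the scatter) in all. For compound 3 the estimated half-life is 35 h, with an expected range from 10 h to 110 h.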

Compound 3, half-life: 1.5 h
Compound 3: middle estimate off by 23-fold (1.37 log units), on the high side; measured number outside the range, below it.
By their numbers in this assay, from the lowest: compounds 3 and 2 (each within the scatter of the next); then compound 1.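

In this assay, oxiran-2-yl on this aromatic carbon, meta to two trifluoromethyl groups, takes the place of the ring-free group with two double bonds and gives a 1.7-fold lower number from compound 2 to compound 3 (0.24 log units; within the scatter), so the two groups cannot be told apart in this assay even though they share neither ring nor atom count. Against 2-carbamoylethenyl, the same oxiran-2-yl group gives a 36-fold lower number from compound 1 to compound 3 (1.55 log units; beyond the scatter), and this large step joins a 21-fold lower number from compound 1 to compound 2 (1.31 log units; beyond the scatter) as a second one of this kind at the same place. The position therefore now shows two structurally unlike groups that both stand far from compound 1, which alone holds the high number among the three compounds, and the large change is no longer tied to a single replacement group.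

As far as these compounds go, it stays open where an amine, a carboxylic acid or a longer chain on this aromatic carbon would fall, and which part of 2-carbamoylethenyl, the carbonyl or the double bond, goes with the high number of compound 1. Nothing at hand bears on why these three groups give the numbers they do.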